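The source may report more compounds than this note shows. Statements on the series, on what has been measured and on what is new or still open speak of the compounds shown alone.

Compound 1 `CCC(C)Sc1nc(Cc2c(F)cccc2Cl)cc(=O)[nH]1` and compound 2 `CCCCSc1nc(Cc2c(F)cccc2Cl)cc(=O)[nH]1` share one core and differ in a single place: butyl in place of sec-butyl on a sulfur. In an ADME assay on MT4 cells (Homo sapiens) for activation, read by MTT assay (a lower number here means that less compound is tolerated, a higher number that more compound is tolerated), compound 1 stops at a limit of the test, > 76000 nM. Compound 2 also stops at a limit, > 76000 nM. The step that the two limits leave unreadable from compound 1 to compound 2 therefore has no readable size, as both values sit at the limit of > 76000 nM in this assay, at which 2 of the 3 values shown sit. Compound 3 `CCC(C)Sc1nc(C(CC)c2c(F)cccc2Cl)c(C)c(=O)[nH]1` carries a different core; the difference between the two cores is not broken down here. In this assay compound 3 reaches only a limit, > 3000 nM, which is the limit of > 3000 nM in this assay, at which 1 of the 3 values shown sits. Compound 4 `CCCCSc1nc(C(CC)c2c(F)cccc2Cl)c(C)c(=O)[nH]1` applies the same change to compound 3: butyl in place of sec-butyl on a sulfur. Because compound 3 stops at the limit > 3000 nM, the step that the limit leaves unreadable from compound 3 to compound 4 is expected to be small. Compound 4 is therefore estimated at 5000 nM, most probably reported again only as a limit.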

Compound 4, half-maximal cytotoxic concentration: > 3000 nM
Compound 4 gave a limit, no number; the forecaster's own chance of this, stated with the estimate: 85%; the middle value does not contradict the limit.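

Compound 3 and compound 4 both end at a limit of the test, and the step between them, butyl in place of sec-butyl on a sulfur, cannot be read. The compounds shown leave open whether this change alters the tolerated concentration in this assay at all.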